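The source may report more compounds than this note shows. Statements on the series, on what has been measured and on what is new or still open speak of the compounds shown alone.

Of the compounds shown here, two have so far been measured in a functional assay on HepG2 cells (Homo sapiens) for inhibition, read by MTT assay, with a stated time of 72 h; a higher number here means a weaker inhibitor, a lower number a stronger inhibitor. Compound 1, `O=C(Nc1ccc(Oc2ccnc3[nH]ccc23)cc1)c1cn(-c2ccc(F)c(Cl)c2)c2ccccc2c1=O`, gives 1120 nM in this assay. Compound 2, `Cn1ccc2c(Oc3ccc(NC(=O)c4cn(-c5ccccc5)c5ccccc5c4=O)cc3F)ccnc21`, gives 2170 nM in this assay. Compound 2 sits at the upper end of the two numbers, but its separation from compound 1 falls within the usual scatter of repeated measurements, so on present evidence the two cannot be told apart.

The next compound, compound 3, `Cn1ccc2c(Oc3ccc(NC(=O)c4cn(-c5ccc(F)cc5)c5ccccc5c4=O)cc3F)ccnc21`, is compound 2 with a single change: fluoro in place of hydrogen on an aromatic carbon. The shared core, the amide link and the ether-linked ring system carrying the fluorine are untouched; only the ring attached to the nitrogen of the core is altered.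

Going by the values given here, no measured pair in this set differs by exactly this change, so there is no direct precedent to draw on. A single fluorine on an aromatic carbon is a small alteration, and compound 1, which carries a fluorine at the same position together with a chlorine, sits within the scatter of compound 2. The step from compound 2 to compound 3 in this assay is therefore expected to be small, most likely no larger than the scatter, with at most a slight drift toward a lower number, an expected 1.2-fold lower number from compound 2 to compound 3 (0.08 log units; within the scatter). Compound 3 is accordingly estimated to give about 1800 nM in this assay, with a range from 700 nM to 4500 nM.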

Compound 3, half-maximal inhibitory concentration: 2010 nM
The estimate for compound 3 lay 1.1-fold (0.05 log units) below the measured number, within the range that was stated.
By their numbers in this assay, from the lowest: compounds 1, 3 and 2 (each within the scatter of the next).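

In this assay, fluoro in place of hydrogen on this ring gives a 1.1-fold lower number from compound 2 to compound 3 (0.03 log units; within the scatter), so the swap from phenyl to 4-fluorophenyl produces no difference that this assay can separate from the ordinary spread of repeat measurements. Going by these compounds alone, this is the first pair here that differs in one place only, which gives the ring position para to a large group a direct reading rather than an inference from compounds that differ in several places: with one added heavy atom at this position, the two compounds cannot be told apart. Nothing available explains why they read alike, and one pair cannot settle that question.

As far as these compounds go, compound 2 and compound 3 carry only hydrogen or fluoro at this position, so it remains open whether a different group there, such as an amine, a methoxy group or a carboxylic acid, would shift the number beyond the scatter. From the compounds shown here alone, it is also open whether fluoro would behave the same way at other positions on this ring, since one step speaks only for the place where it was read.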